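Fluoro to chloro on the aryl ketone of compound 2

The compounds below may be only part of what the source reports. "The series", "measured", "known", "first", "only" and "open" are said of these compounds alone.

Among the measured compounds shown here, compound 2 `COc1ccc(/C=C/c2cc(OC)cc(OC)c2/C=C/C(=O)c2ccc(F)cc2)cc1` gives 6.6 ug/mL in a functional assay on A549 cells (Homo sapiens) for antiproliferative activity, read by MTT assay, with a stated time of 48 h (a higher number here means a weaker inhibitor, a lower number a stronger inhibitor), the lower of the two numbers so far, a gap to compound 1 `CCCCOc1ccc(C(=O)/C=C/c2c(/C=C/c3ccc(OC)cc3)cc(OC)cc2OC)cc1`, which gives 8.7 ug/mL, that lies within the scatter (a 1.3-fold lower number from compound 1 to compound 2 (0.12 log units; within the scatter)). Compound 3 `COc1ccc(/C=C/c2cc(OC)cc(OC)c2/C=C/C(=O)c2ccc(Cl)cc2)cc1` differs from compound 2 by chloro in place of fluoro on an aromatic carbon. For the measured compounds named here, the only measured step on that aromatic carbon, butoxy to fluoro, stayed within the scatter, and no halogen-to-halogen step has been measured. The expected step in this assay is therefore small, a 1.1-fold lower number from compound 2 to compound 3 (0.04 log units; within the scatter), in no direction beyond the scatter. Compound 3 is estimated at 6 ug/mL, between 3.5 ug/mL and 11 ug/mL.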

Compound 3, half-maximal inhibitory concentration: 6.4 ug/mL
Beside the measured number, compound 3's estimate is 1.1-fold (0.03 log units) below it, and the stated range covers the measured number.
By their numbers in this assay, from the lowest: compounds 3, 2 and 1 (each within the scatter of the next).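

In this assay, the halogen swap on this aromatic carbon changes nothing that can be read (a 1.0-fold lower number from compound 2 to compound 3 (0.01 log units; within the scatter)). The larger replacement of butoxy by chloro at the same carbon also stays within the scatter (a 1.4-fold lower number from compound 1 to compound 3 (0.13 log units; within the scatter)), so the butoxy, fluoro and chloro compounds cannot be ranked, and this position has so far tolerated all three groups without a readable difference. Nothing available bears on why these groups read alike.

Going by these compounds, whether an amine or a carboxylic acid at this position would separate from these three remains open. So does whether any change elsewhere on the shared core would move the number beyond the scatter.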